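This account rests on a few compounds, and the source may have more. Where it says the series, first, only, none or still open, it means among the compounds named here.

Of the compounds shown here, three built on the same core have been tested in a functional assay on Malme-3M cells (Homo sapiens) for inhibition, read by sulforhodamine B assay, with a stated time of 48 h; a higher number here means that more compound is tolerated, a lower number that less compound is tolerated. Compound 1 `Nc1cc(N)c2nc(-c3ccccc3)c(NCc3ccc(Cl)c(Cl)c3)nc2c1` gives 50100 nM in this assay. Compound 2 `CCOC(=O)[C@H](CCC(=O)O)NC(=O)c1ccc(Sc2nc3cc(N)cc(N)c3nc2-c2ccccc2)cc1` gives 70800 nM, and compound 3 `CCOC(=O)[C@H](CCC(=O)O)NC(=O)c1ccc(Oc2nc3cc(N)cc(N)c3nc2-c2ccccc2)cc1` gives 66100 nM. Compound 1 thus has the lowest of the three numbers, yet its gaps to compound 3 and to compound 2 both lie within the usual scatter of this assay, so the three compounds cannot be told apart on these measurements alone; all three need a high concentration before the cells are killed to the extent this read-out measures.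

Compound 4 `COc1ccc(CNc2nc3cc(N)cc(N)c3nc2-c2ccccc2)cc1` has not yet been measured. It differs from compound 1 in one place: 4-methoxyphenyl in place of 3,4-dichlorophenyl on a saturated chain carbon bound to a nitrogen on an aromatic ring. For the measured compounds named here, no pair of measured compounds shows the effect of such a swap, so there is nothing in the numbers above that points in either direction. The three measured compounds, which differ from one another far more than compound 1 and compound 4 do, all sit close together, which suggests the core rather than the group on the chain carbon sets the level here. The step from compound 1 to compound 4 is therefore expected to be small, a 1.2-fold higher number from compound 1 to compound 4 (0.08 log units; within the scatter), not beyond the scatter in either direction. Compound 4 is expected to give about 60000 nM in this assay, with a likely range from 25000 nM to 150000 nM.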

Compound 4, concentration lethal to 50% of the cells: 47900 nM
Estimate against measurement, compound 4: 1.3-fold (0.10 log units) above, within the range that was stated.
By their numbers in this assay, from the lowest: compounds 4, 1, 3 and 2 (each within the scatter of the next).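

In this assay, for the compounds shown here, putting 4-methoxyphenyl in place of 3,4-dichlorophenyl on a saturated chain carbon bound to a nitrogen on an aromatic ring gives a 1.0-fold lower number from compound 1 to compound 4 (0.02 log units; within the scatter), which lies within the scatter and is the first direct reading of a single change at this place. The swap removes both chlorine atoms and brings in an oxygen with one hydrogen-bond acceptor while the heavy-atom count stays the same, yet this assay does not tell the two groups apart, so for this pair the choice of substituents on the ring makes no measurable difference. No measurement at hand says why the two groups read alike.

Both groups are six-membered aromatic rings of carbon, so the compounds shown leave open whether a group of another kind at this place, such as a carboxylic acid or an amine in place of the 4-methoxyphenyl, would move the number beyond the scatter. As far as these compounds go, a longer chain between the nitrogen and the ring is equally open, and so is whether any change at this place can bring the number down.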